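One Stereocentre Inverted: Expecting Compound 3

This account rests on a few compounds, and the source may have more. Where it says the series, first, only, none or still open, it means among the compounds named here.

Compound 1, `CCCCC/C=C\C[C@@H](O)[C@H](O)/C=C/[C@@H]1C/C=C\CCCC(=O)O1`: 14.7 ug/mL
Compound 2, `CC/C=C\C/C=C\C[C@@H](O)[C@H](O)/C=C/[C@@H]1C/C=C\CCCC(=O)O1`: 11.6 ug/mL

In a functional assay on HCT-15 cells (Homo sapiens) for cytotoxicity (a lower number here means that less compound is needed, a higher number that more compound is needed for the effect), compound 2 gives 11.6 ug/mL, and compound 1 sits within the scatter of it: a 1.3-fold lower number from compound 1 to compound 2 (0.10 log units; within the scatter). Compound 3, `CC/C=C\C/C=C\C[C@H](O)[C@H](O)/C=C/[C@@H]1C/C=C\CCCC(=O)O1`, differs from compound 2 only in configuration: the two compounds have the same atoms and bonds and differ only in configuration as drawn: 1 of 7 stereo elements differ; a stereocentre at a saturated chain carbon is drawn R in compound 2 and S in compound 3. For the measured compounds named here, the single measured step swapped a chain group and stayed within the scatter; no measured step inverts a stereocentre, so nothing here shows how such an inversion moves the number. The expected step of a 1.0-fold higher number from compound 2 to compound 3 (0.01 log units; within the scatter) is therefore none beyond the scatter, with wide uncertainty. Compound 3 is estimated at 12 ug/mL, within a range of 4 ug/mL to 35 ug/mL.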

Compound 3, concentration for half-maximal effect: 7.6 ug/mL
The estimate for compound 3 lay 1.6-fold (0.20 log units) above the measured number; measured number inside the range.
By their numbers in this assay, from the lowest: compounds 3, 2 and 1 (each within the scatter of the next).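

Across this stereocentre at a saturated chain carbon, this assay gives a 1.5-fold lower number from compound 2 to compound 3 (0.18 log units; within the scatter). Inverting this one carbon therefore produces no change beyond the scatter, something the earlier chain swap could not show. The comparison is a clean one, with a single point of difference: the fact that compounds 2 and 3 differ only in the configuration as drawn

The compounds shown leave open whether inverting this carbon in the chain of compound 1 would behave the same way. They also leave open whether an amine or a methoxy group in place of the hydroxyl on this carbon would move the number beyond the scatter.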